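Shifting the chloro group on the triazole-linked phenyl

This account rests on a few compounds, and the source may have more. Where it says the series, first, only, none or still open, it means among the compounds named here.

Measured values in a functional assay on A549 cells (Homo sapiens) for antiproliferative activity, read by MTT assay, with a stated time of 24 h; on this read-out lower numbers stand for stronger inhibition and higher numbers for weaker inhibition:
compound 1 `O=c1[nH]cc(S(=O)(=O)Nc2ccccc2-c2cn(-c3ccccc3Cl)nn2)c(=O)[nH]1`: 2740 nM
compound 2 `O=c1[nH]cc(S(=O)(=O)Nc2ccccc2-c2cn(-c3cccc(Cl)c3)nn2)c(=O)[nH]1`: 2340 nM
compound 3 `Cc1ccccc1-n1cc(-c2cccc(NS(=O)(=O)c3c[nH]c(=O)[nH]c3=O)c2)nn1`: 5470 nM

Compound 3 gives the highest number of the three; its gap to compound 1 lies within the scatter, while its gap to compound 2 lies beyond it. Compound 4 `O=c1[nH]cc(S(=O)(=O)Nc2cccc(-c3cn(-c4ccc(Cl)cc4)nn3)c2)c(=O)[nH]1` differs from compound 3 in one place: 4-chlorophenyl in place of 2-methylphenyl on an aromatic nitrogen. Among the compounds with values here, the only measured step that bears on this change is a 1.2-fold lower number from compound 1 to compound 2 (0.07 log units; within the scatter), where moving the chlorine on the same phenyl barely altered the result. Exchanging a methyl for a chlorine at another position is therefore expected to give, in this assay, no step beyond the scatter; compound 4 is estimated at 4500 nM (range 2000 nM to 10000 nM), an expected step of a 1.2-fold lower number from compound 3 to compound 4 (0.08 log units; within the scatter).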

Compound 4, half-maximal inhibitory concentration: 1730 nM
Beside the measured number, compound 4's estimate is 2.6-fold (0.42 log units) above it, outside the stated range (below it).
By their numbers in this assay, from the lowest: compounds 4, 2, 1 and 3 (each within the scatter of the next, the first and the last beyond it).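

In this assay the step to 4-chlorophenyl from 2-methylphenyl on the aromatic nitrogen gives a 3.2-fold lower number from compound 3 to compound 4 (0.50 log units; beyond the scatter) and so shows that a change at this position can exceed the scatter. The earlier chlorine shift gave only a 1.2-fold lower number from compound 1 to compound 2 (0.07 log units; within the scatter) on a different placement of the shared core. No measurement shown explains why the number fell.

This single step changes both the group and where it carries its substituent, so the two contributions cannot be separated. A 4-methylphenyl or 2-chlorophenyl on this same core would help separate them.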